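Permeability notes on a shared-core series, compound 4

A few compounds are considered here, and "the series" means these few. Any claim that something is new, unique, unknown or untested is made for them only; others in the source may bear on it.

Compound 1 `CC(C)Nc1nc(NCc2ccco2)c2ccccc2n1`: 62.2 10^-6 cm/s
Compound 2 `CSCCNc1nc(NC(C)C)nc2ccccc12`: 28.8 10^-6 cm/s
Compound 3 `CC(C)Nc1nc(NC2CCCCC2)c2ccccc2n1`: 112 10^-6 cm/s

In a physicochemical assay for permeability, using PAMPA, at pH 4 (on this read-out higher numbers stand for higher permeability and lower numbers for lower permeability), compound 1 gives 62.2 10^-6 cm/s, the second highest of the three numbers. The nearest neighbour is compound 3, which gives 112 10^-6 cm/s; the step of a 1.8-fold higher number from compound 1 to compound 3 (0.26 log units; within the scatter) stays within the scatter. The furthest is compound 2, which gives 28.8 10^-6 cm/s; the step of a 2.2-fold lower number from compound 1 to compound 2 (0.33 log units; beyond the scatter) is beyond the scatter, as is a 3.9-fold higher number from compound 2 to compound 3 (0.59 log units; beyond the scatter).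

Compound 4 `COc1ccc2c(NCc3ccco3)nc(NC(C)C)nc2c1` differs from compound 1 in one place: methoxy in place of hydrogen on an aromatic carbon. All three measured steps change the group on a nitrogen on an aromatic ring or the chain attached to it; none touches an aromatic carbon of the six-membered carbon ring of the shared core. Among the compounds with values here, there is thus no measured step that bears directly on the change from compound 1 to compound 4, and the steps that do exist are modest or within the scatter. Without a comparable precedent, compound 4 is expected to land close to compound 1, with a 1.1-fold lower number from compound 1 to compound 4 (0.05 log units; within the scatter), most likely within the scatter and with no clear direction. For compound 4 the estimate is 55 10^-6 cm/s, with a range from 28 10^-6 cm/s to 110 10^-6 cm/s.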

Compound 4, apparent permeability: 59.2 10^-6 cm/s
For compound 4 the middle estimate is 1.1-fold (0.03 log units) below the measured one, within the range that was stated.
By their numbers in this assay, from the lowest: compound 2; then compounds 4, 1 and 3 (each within the scatter of the next).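

In this assay, methoxy in place of hydrogen on an aromatic carbon of the six-membered aromatic ring of carbon only gives a 1.1-fold lower number from compound 1 to compound 4 (0.02 log units; within the scatter) and is the first step shown at this part of the shared core. Here, on the background of compound 1, the change stays within the scatter, whereas the step on a nitrogen on an aromatic ring that gives a 3.9-fold higher number from compound 2 to compound 3 (0.59 log units; beyond the scatter) lies beyond it, so this single pair shows a substituent on this aromatic carbon with no readable effect on the number. No measured property of these compounds is at hand to account for this result.

The compounds shown leave open whether an amine, a carboxylic acid or a longer alkoxy chain on this same aromatic carbon would also stay within the scatter. They also leave open whether methoxy here gives an equally small step when the nitrogen carries cyclohexyl, as in compound 3, or 2-(methylsulfanyl)ethyl, as in compound 2.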